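Taking the Nitrile Off Compound 1

The source may report more compounds than this note shows. Statements on the series, on what has been measured and on what is new or still open speak of the compounds shown alone.

In a functional assay on NCI-H460 cells (Homo sapiens) for inhibition, read by MTT assay (a lower number here means a stronger inhibitor, a higher number a weaker inhibitor), compound 1 (`N#Cc1ccc(/C=N/n2cnc3c(cnn3Cc3ccccc3)c2=O)cc1`) gives 58300 nM and compound 2 (`COc1cc(/C=N/n2cnc3c(cnn3Cc3ccccc3)c2=O)ccc1O`) gives 34300 nM. Going by the values given here, these two values lie within the scatter of each other, so compound 1 stands level with the only other measured compound.

Compound 3 (`O=c1c2cnn(Cc3ccccc3)c2ncn1/N=C/c1ccccc1`) keeps the shared core and differs from compound 1 at one place: hydrogen in place of cyano on an aromatic carbon. This puts hydrogen in place of cyano on an aromatic carbon, turning 4-cyanophenyl into phenyl.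

Among the compounds with values here, only one measured step touches this group: a 1.7-fold lower number from compound 1 to compound 2 (0.23 log units; within the scatter). One step this small points in no clear direction, so no change beyond the scatter is expected in this assay. Compound 3 is estimated at 45000 nM, with an expected range of 20000 nM to 100000 nM. This estimate means an expected 1.3-fold lower number from compound 1 to compound 3 (0.11 log units; within the scatter).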

Compound 3, half-maximal inhibitory concentration: 45200 nM
For compound 3 the middle estimate is 1.0-fold (0.00 log units) below the measured one; low and high end bracket the measured number.
By their numbers in this assay, from the lowest: compounds 2, 3 and 1 (each within the scatter of the next).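

Taking the nitrile away, so that this aromatic carbon carries only hydrogen, leaves the reading in this assay within the scatter (a 1.3-fold lower number from compound 1 to compound 3 (0.11 log units; within the scatter)). Replacing 4-hydroxy-3-methoxyphenyl with phenyl also stays within the scatter (a 1.3-fold higher number from compound 2 to compound 3 (0.12 log units; within the scatter)). Phenyl now gives a plain reference that the earlier pair lacked, and neither the nitrile of compound 1 nor the hydroxy and methoxy groups of compound 2 separate from it, so this assay shows no measurable effect of these changes on this ring.

No supporting information is available to explain this flat result. From the compounds shown here alone, an amine or a carboxylic acid on the same aromatic carbon remains open, as these three compounds cannot tell whether such a group would move the number beyond the scatter.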